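The source may hold more compounds than are shown below. What is called first, only, known or untested is meant among the compounds shown, and "the series" means these compounds.

Measured in a functional assay on CHO cells with adenosine receptor A1 (Homo sapiens) as the target, read by cAMP accumulation and immunoassay, with a stated time of 6 min, tested at 1 uM; a higher number here means a weaker effect of the compound at the concentration tested, a lower number a stronger effect:

compound 1 `Nc1scc(CN2CCN(c3ccncc3)CC2)c1C(=O)c1ccc(Cl)cc1` gives -8.3%
compound 2 `Nc1scc(CN2CCN(c3ccc(C(F)(F)F)cc3)CC2)c1C(=O)c1cccc(C(F)(F)F)c1` gives -27%
compound 3 `Nc1scc(CN2CCN(c3c(F)cccc3F)CC2)c1C(=O)c1cccc(C(F)(F)F)c1` gives 1.3%

Compound 1 stands second highest of the three numbers. Compound 3 is its nearest neighbour, and the two lie within the usual scatter of each other; compound 2 lies lower than compound 1, beyond the scatter. Compound 4 `Nc1scc(CN2CCN(c3ccc(F)c(Cl)c3)CC2)c1C(=O)c1ccc(Cl)cc1` is not yet measured in this assay. The change from compound 1 to compound 4 is 3-chloro-4-fluorophenyl in place of pyridin-4-yl on an amine nitrogen in a ring.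

Among the measured compounds shown here, the only measured step at that same place is the aryl swap a number 28.3 percentage points higher from compound 2 to compound 3 (beyond the scatter), a modest rise. It exchanges one substituted phenyl for another, whereas the step to compound 4 exchanges pyridin-4-yl for a substituted phenyl, so it bears on the present step only loosely, and the shared core of compound 1 also differs from that of compounds 2 and 3 in the aroyl part. The spread among all three measured values is itself not wide. For compound 4 a step of about a number 1.7 percentage points lower from compound 1 to compound 4 (within the scatter) is expected, that is, none clearly beyond the scatter. The estimate for compound 4 in this assay is -10%, with a range from -30% to 10%.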

Compound 4, a percentage reported as activity, at one concentration (the size of the read-out at that concentration, not a potency): -60%
Estimate against measurement, compound 4: 50 percentage points above, and the stated range ends above it.
By their numbers in this assay, from the lowest: compound 4; then compound 2; then compounds 1 and 3 (each within the scatter of the next).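

In this assay, the step of a number 51.7 percentage points lower from compound 1 to compound 4 (beyond the scatter) shows that, with the core of compound 1 held fixed, the group on the amine nitrogen in a ring can move the read-out by a large amount, towards a stronger effect at the concentration tested. This change replaces pyridin-4-yl, a ring with a nitrogen, with 3-chloro-4-fluorophenyl, a ring of carbon only, so a single step combines the loss of the ring nitrogen with the arrival of both halogens. Nothing available explains the size of this step.

Still open, going by these compounds, is how an unsubstituted phenyl on the same nitrogen would read, which would help divide the step between those two parts of the change. Also open, on these data alone, is whether a methoxy group on that ring would keep the effect.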